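Compound 2 and its sulfomethyl counterpart, compound 4

The source may hold more compounds than are shown below. What is called first, only, known or untested is meant among the compounds shown, and "the series" means these compounds.

Compound 1 `CC(=O)CCSC(=S)NCc1cccnc1`: 1120 nM
Compound 2 `O=C(O)CCSC(=S)NCc1cccnc1`: 7970 nM
Compound 3 `CCCCOC(=O)CCSC(=S)NCc1cccnc1`: 4460 nM

In a functional assay on SK-BR-3 cells (Homo sapiens) for cytotoxicity, read by resazurin assay, with a stated time of 72 h (a lower number here means a stronger inhibitor, a higher number a weaker inhibitor), compound 2 stands at the weak end of this small set, level with compound 3 within the scatter: a 1.8-fold lower number from compound 2 to compound 3 (0.25 log units; within the scatter). Compound 1 stands apart from both, with a 7.1-fold higher number from compound 1 to compound 2 (0.85 log units; beyond the scatter) and a 4.0-fold higher number from compound 1 to compound 3 (0.60 log units; beyond the scatter).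

Compound 4 `O=S(=O)(O)CCCSC(=S)NCc1cccnc1` keeps the shared core and alters the end of the chain: sulfomethyl in place of carboxy on a saturated chain carbon, two bonds along the chain from a sulfur. This places sulfomethyl in place of carboxy on a saturated chain carbon, two bonds along the chain from a sulfur.

Among the measured compounds shown here, no measured step makes this exchange directly. The closest evidence comes from the same chain end, where replacing hydrogen with butyl on the oxygen of compound 2 stayed within the scatter, while the modest steps both start from compound 1. Compound 4 is therefore expected to remain close to compound 2, with no clear shift beyond the scatter. The expected step is a 1.3-fold higher number from compound 2 to compound 4 (0.10 log units; within the scatter). For compound 4 the estimate is 10000 nM, with an expected range of 3500 nM to 30000 nM.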

Compound 4, half-maximal inhibitory concentration: 6770 nM
Estimate against measurement, compound 4: 1.5-fold (0.17 log units) above, within the range that was stated.
By their numbers in this assay, from the lowest: compound 1; then compounds 3, 4 and 2 (each within the scatter of the next).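

In this assay, the exchange of carboxy for sulfomethyl on a saturated chain carbon, two bonds along the chain from a sulfur, gives a 1.2-fold lower number from compound 2 to compound 4 (0.07 log units; within the scatter) and so shows that this larger acid-bearing group reads level with carboxy at this position. The separation of compound 1 also holds for this new chain end, with a 6.0-fold higher number from compound 1 to compound 4 (0.78 log units; beyond the scatter) as its step, which leaves compound 1, with its acetyl group, apart from compound 2, compound 3 and compound 4. No measurement available here bears on why carboxy and sulfomethyl read alike or why acetyl reads differently.

The compounds shown leave open how an amine or a hydroxy group at this chain end would read. They also leave open whether a ketone carrying a longer chain than the acetyl group of compound 1 would stay apart from compound 2 and compound 4.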